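A few compounds are considered here, and "the series" means these few. Any claim that something is new, unique, unknown or untested is made for them only; others in the source may bear on it.

Among the three compounds measured in a functional assay on CFPAC-1 cells (Homo sapiens) for antiproliferative activity, read by MTT assay, with a stated time of 72 h (a higher number here means a weaker inhibitor, a lower number a stronger inhibitor), compound 1 `Cc1ccc(S(=O)(=O)NCc2cn(C[C@H](O)[C@H]3OC(=O)C(OCc4ccccc4)=C3OCc3ccccc3)nn2)cc1` stands highest of the two finite numbers, giving 68000 nM. Its nearest neighbour is compound 3 `O=C1O/C(=C\Cn2cc(-c3cccc(O)c3)nn2)C(OCc2ccccc2)=C1OCc1ccccc1`, which gives 33700 nM, a gap within the scatter. Compound 2 `Cc1ccc(-c2cn(C/C=C3\OC(=O)C(OCc4ccccc4)=C3OCc3ccccc3)nn2)cc1` reaches only the limit of > 100000 nM in this assay, at which 1 of the 3 values shown sits, and is reported at > 100000 nM. For the measured compounds named here, the one step measured between these compounds, an at least 2.9-fold lower number from compound 2 to compound 3 (0.47 log units; beyond the scatter), lies beyond the scatter and shows the 3-hydroxyphenyl variant reading lower than its 4-methylphenyl counterpart.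

Compound 4 `CCCCCc1ccc(-c2cn(C[C@H](O)[C@H]3OC(=O)C(OCc4ccccc4)=C3OCc3ccccc3)nn2)cc1` arises from compound 1 through (4-pentylphenyl in place of (((4-methylphenyl)sulfonyl)amino)methyl on an aromatic carbon). Going by the values given here, no measured step touches this exact change. Among the compounds with values here, the only measured compound that carries an alkyl-bearing aryl group directly on the same ring is compound 2, and it sits at the limit rather than at a number. A 4-pentylphenyl group is therefore expected to leave compound 4 no stronger than compound 1, and the expected step of a 1.2-fold higher number from compound 1 to compound 4 (0.07 log units; within the scatter) is small or none beyond the scatter. Compound 4 is estimated at 80000 nM, within 30000 nM to 200000 nM.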

Compound 4, half-maximal inhibitory concentration: 9890 nM
Estimate against measurement, compound 4: 8.1-fold (0.91 log units) above; the measured number lies below the stated range.
By their numbers in this assay, from the lowest: compound 4; then compounds 3 and 1 (each within the scatter of the next). At a limit, above all of these: compound 2.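

In this assay, this aromatic carbon of the five-membered ring responds to the group it carries: 4-pentylphenyl in place of (((4-methylphenyl)sulfonyl)amino)methyl gives a 6.9-fold lower number from compound 1 to compound 4 (0.84 log units; beyond the scatter) on the core of compound 1. The lower number comes with a group that has 0 hydrogen-bond donors and 0 hydrogen-bond acceptors, so the donor and acceptors of the leaving group are not needed for a reading at this level at this position. Compound 2 also carries an alkyl-bearing phenyl group on this ring, but its value is a limit and not a number: the limit of > 100000 nM in this assay, at which 1 of the 4 values shown sits.

For the compounds shown here, the single step changes the link to the ring and the aryl substituent together, so it does not separate the pentyl chain from the directly attached phenyl ring. Going by these compounds, how a 4-butylphenyl or 4-hexylphenyl group, or an amine or carboxylic acid at the end of the chain, would read remains open.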